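This account rests on a few compounds, and the source may have more. Where it says the series, first, only, none or still open, it means among the compounds named here.

Measured so far:
- compound 1 `NC(=O)c1ccc(NCc2nc(-c3ccccc3)nn2-c2ccccc2)cc1`: -4.4%
- compound 2 `O=C(NO)c1ccc(NCc2nc(-c3ccccc3)nn2-c2ccc(F)cc2)cc1`: 67.6%
- compound 3 `Cc1ccc(-c2nc(CNc3ccc(C(=O)NO)cc3)n(-c3ccccc3)n2)s1`: 79.7%

In an assay on Sf9 cells for inhibition of protein deacetylase HDAC6 (Homo sapiens), read by fluorescence, with a stated time of 40 min, tested at 100 nM (on this read-out higher numbers stand for more inhibition at the one concentration tested (going by the name of the read-out) and lower numbers for less inhibition), compound 3 gives the highest of the three numbers. Its nearest neighbour is compound 2, lower by a margin beyond the usual scatter; the furthest is compound 1, whose number lies far lower, also well beyond the scatter. Among the measured compounds shown here, no pair of measured compounds differs in a single place, so no step size is known from the measured set.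

Compound 4 `O=C(NO)c1ccc(NCc2nc(-c3ccccc3)nn2-c2ccccc2)cc1` is the next compound to be measured. It differs from compound 3 in one place: phenyl in place of 5-methylthiophen-2-yl on an aromatic carbon. For the measured compounds named here, no measured step matches this change. A small step down in this assay is expected, of a size that may lie within the scatter. The estimate for compound 4 rests partly on compound 2, which gives 67.6% in this assay with the same hydroxamic acid and a phenyl in the place concerned. Compound 4 is therefore estimated at 68%, in the range 52% to 82%, meaning an expected step of a number 11.7 percentage points lower from compound 3 to compound 4 (beyond the scatter).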

Compound 4, a percentage reported as inhibition, at one concentration (the size of the read-out at that concentration, not a potency): 72.6%
Compound 4: the middle estimate sits 4.6 percentage points below what was measured, and the stated range covers the measured number.
By their numbers in this assay, from the lowest: compound 1; then compounds 2, 4 and 3 (each within the scatter of the next, the first and the last beyond it).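

At this aromatic carbon of the five-membered aromatic ring with 3 nitrogen, phenyl and 5-methylthiophen-2-yl cannot be told apart in this assay (a number 7.1 percentage points lower from compound 3 to compound 4 (within the scatter)), so this change of ring leaves the read-out within the scatter. Hydrogen in place of fluoro on an aromatic carbon of the other phenyl also stays within the scatter (a number 5 percentage points higher from compound 2 to compound 4 (within the scatter)). The large change comes with hydroxy in place of hydrogen on the amide-type nitrogen (a number 77 percentage points higher from compound 1 to compound 4 (beyond the scatter)), the first single-place measure of what that hydroxy group contributes in this series.

Going by these compounds, how an amine, a carboxylic acid or a longer alkyl chain would fare at the ring position remains open, and the read-out shows only the size of the effect at a single concentration. No measurement at hand gives a reason for any of these steps.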